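The source may report more compounds than this note shows. Statements on the series, on what has been measured and on what is new or still open speak of the compounds shown alone.

Working notes on the series. Compound 1 `COc1cccc(Cn2cc(CCc3cc(OC)c(OC)c(OC)c3)c3c(C)nc(N)nc32)c1` and compound 2 `COc1ccc(Cn2cc(CCc3cc(OC)c(OC)c(OC)c3)c3c(C)nc(N)nc32)cc1OC` share one core; compound 3 `COc1ccccc1Sc1cn(Cc2ccccc2)c2nc(N)nc(C)c12` and the still unmeasured compound 4 `COc1ccccc1Cn1cc(Sc2ccccc2OC)c2c(C)nc(N)nc21` share another. The difference between the two cores is not broken down here. In a functional assay on JC cells (Mus musculus) for inhibition, read by sulforhodamine B assay, with a stated time of 48 h (on this read-out higher numbers stand for weaker inhibition and lower numbers for stronger inhibition), compound 1 gives 1400 nM, and compound 2 gives 1500 nM; the change methoxy in place of hydrogen on an aromatic carbon made a step of a 1.1-fold higher number from compound 1 to compound 2 (0.03 log units; within the scatter). Compound 3 gives 11000 nM in this assay, the highest number of the three measured. The change methoxy in place of hydrogen on an aromatic carbon is the same kind of change, but its place differs: on compound 1 the entering group stands ortho to a methoxy group and para to a large group, whereas on compound 3 it stands ortho to a large group. Because a 1.1-fold higher number from compound 1 to compound 2 (0.03 log units; within the scatter) lay within the scatter, a step of about a 1.1-fold lower number from compound 3 to compound 4 (0.04 log units; within the scatter) from compound 3 to compound 4 is expected in this assay. Compound 4 is thus estimated at 10000 nM, between 4000 nM and 25000 nM.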

Compound 4, half-maximal inhibitory concentration: 9000 nM
Compound 4: middle estimate off by 1.1-fold (0.05 log units), on the high side, within the range that was stated.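

In this assay, the methoxy change gave a step of a 1.2-fold lower number from compound 3 to compound 4 (0.09 log units; within the scatter). Set beside the earlier step, it shows no difference between the two cores that can be told from the scatter: the same change on two cores in this assay, a 1.1-fold higher number (0.03 log units; within the scatter) from compound 1 to compound 2 and a 1.2-fold lower number (0.09 log units; within the scatter) from compound 3 to compound 4, 1.3-fold (0.12 log units) apart, within the scatter of two such steps This supports carrying the change from one core to the other only as a step within the scatter, in this one assay and at the places on the ring seen here; one pair per core does not show that it would hold at other places or on other cores.

Still open, going by these compounds, is whether an amine, a carboxylic acid or a longer alkoxy chain on the benzyl group would give a step beyond the scatter. On these data alone, the effect of the difference between the two cores also stays open.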